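The source may hold more compounds than are shown below. What is called first, only, known or untested is meant among the compounds shown, and "the series" means these compounds.

Measured compounds:
compound 1 `CNc1nc2c(C(=O)N[C@@H]3CN4CCC3CC4)cccc2o1`, 36.4 nM
compound 2 `CCNc1nc2c(C(=O)N[C@@H]3CN4CCC3CC4)cccc2o1`, 36.4 nM

In an assay on isolated protein for binding affinity to 5-hydroxytryptamine receptor 3A (Homo sapiens) (on this read-out lower numbers stand for stronger inhibition and higher numbers for weaker inhibition), compound 1 gives 36.4 nM and compound 2 gives 36.4 nM; the two are level at the digits shown, and the one measured step, no change at the digits printed from compound 1 to compound 2 (within the scatter), shows that lengthening the chain on the nitrogen that sits on the aromatic ring is tolerated without a shift beyond the scatter.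

Compound 3 `CN(C)c1nc2c(C(=O)N[C@@H]3CN4CCC3CC4)cccc2o1` follows from compound 2 by dimethylamino in place of ethylamino on an aromatic carbon: the hydrogen-bond donor on that nitrogen is given up while the acceptor is kept. Among the measured compounds shown here, no measured pair tests a loss of this donor; the only step at hand concerns chain length and was flat. The outcome is therefore open, and a step in this assay of modest size, weakening rather than strengthening, is the working expectation, with no change beyond the scatter a real possibility.

For compound 3 the estimated value in this assay is 70 nM, a step of a 1.9-fold higher number from compound 2 to compound 3 (0.28 log units; within the scatter), within a range of 20 nM to 300 nM.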

Compound 3, inhibition constant: 18.2 nM
Estimate against measurement, compound 3: 3.8-fold (0.59 log units) above, outside the stated range (below it).
By their numbers in this assay, from the lowest: compounds 3, 1 and 2 (each within the scatter of the next).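

In this assay, the group on this aromatic carbon can give up its hydrogen-bond donor without a shift beyond the scatter: dimethylamino in place of ethylamino gives (a 2.0-fold lower number from compound 2 to compound 3 (0.30 log units; within the scatter)), and methyl in place of hydrogen on the nitrogen gives (a 2.0-fold lower number from compound 1 to compound 3 (0.30 log units; within the scatter)). The earlier pair addressed only chain length on a nitrogen that kept its donor, whereas these steps show that the level holds with 0 hydrogen-bond donors on the group as well as with 1. Nothing at hand gives a reason for this tolerance.

Still open, going by these compounds, is whether the position accepts a larger group, such as a longer chain like butylamino or a ring like morpholine. Equally open, on these data alone, is what happens when the nitrogen is replaced altogether, as with a methoxy group or a plain hydrogen.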